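The compounds below may be only part of what the source reports. "The series", "measured", "known", "first", "only" and "open" are said of these compounds alone.

Working notes on the series. Compound 1 `Nc1cc(N)c2nc(-c3ccccc3)c(NCc3ccc(F)cc3)nc2c1` and compound 2 `COc1ccc(CNc2nc3cc(N)cc(N)c3nc2-c2ccccc2)cc1` share one core. In a functional assay on SF-268 cells (Homo sapiens) for inhibition, read by sulforhodamine B assay, with a stated time of 48 h (on this read-out higher numbers stand for lower toxicity in this test and lower numbers for higher toxicity in this test), compound 1 gives 40700 nM, and in this assay compound 2 gives 49000 nM. The change between them is methoxy in place of fluoro on an aromatic carbon, and it reads a 1.2-fold higher number from compound 1 to compound 2 (0.08 log units; within the scatter). Compound 3 `COc1ccc(Sc2nc3cc(N)cc(N)c3nc2-c2ccccc2)cc1` carries (4-methoxyphenyl)sulfanyl in place of the (4-fluorobenzyl)amino group of compound 1; that step reads a step that the limit leaves unreadable from compound 1 to compound 3. In this assay compound 3 gives only a limit, < 100000 nM, as recorded in the limit of < 100000 nM in this assay, at which 1 of the 3 values shown sits. Where compound 3 stands is thus known only as this limit, not as a number.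

Compound 4 `Nc1cc(N)c2nc(-c3ccccc3)c(Sc3ccc(F)cc3)nc2c1` is the next step: fluoro in place of methoxy on an aromatic carbon. For the measured compounds named here, the one measured step of the same kind, a 1.2-fold higher number from compound 1 to compound 2 (0.08 log units; within the scatter), runs the other way and stays within the scatter, so in this assay no step beyond the scatter is expected in either direction. Compound 4 is therefore estimated at 50000 nM, with a range from 15000 nM to 100000 nM. The expected step this estimate means is a step that the limit leaves unreadable from compound 3 to compound 4.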

Compound 4, concentration lethal to 50% of the cells: 85100 nM
Compound 4: middle estimate off by 1.7-fold (0.23 log units), on the low side, within the range that was stated.
By their numbers in this assay, from the lowest: compounds 1, 2 and 4 (each within the scatter of the next, the first and the last beyond it).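

In this assay, (4-fluorophenyl)sulfanyl in place of (4-fluorobenzyl)amino on the shared core gives a 2.1-fold higher number from compound 1 to compound 4 (0.32 log units; beyond the scatter). For the compounds shown here, this is the only readable step beyond the scatter, so exchanging the whole group at this position moves the number, though modestly, while the readable exchange on the outer aromatic ring, a 1.2-fold higher number from compound 1 to compound 2 (0.08 log units; within the scatter), does not. The step from compound 3 to compound 4 cannot be read, and neither can the step from compound 1 to compound 3, because compound 3 stands only as a limit: the limit of < 100000 nM in this assay, at which 1 of the 4 values shown sits.

On these data alone, whether methoxy and fluoro differ on the (4-methoxyphenyl)sulfanyl and (4-fluorophenyl)sulfanyl groups therefore stays open. Also open, as far as these compounds go, is how an amine or a carboxylic acid in place of fluoro on that six-membered aromatic ring would read in this assay.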